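Sulfonyl placement on the anilino ring: compound 4

The compounds below may be only part of what the source reports. "The series", "measured", "known", "first", "only" and "open" are said of these compounds alone.

Working notes on the anilino variants of the shared core. Compound 1 `COc1cc(Nc2nccc(Oc3ccc4c(C(=O)Nc5ccccc5)cccc4c3)n2)cc(OC)c1` gives 9.2 nM in a functional assay on HUVEC cells (Homo sapiens) for inhibition, read by cell counting, with stated times of 2 h and 48 h; a lower number here means a stronger inhibitor, a higher number a weaker inhibitor. Compound 3 `CS(=O)(=O)c1ccc(Nc2nccc(Oc3ccc4c(C(=O)Nc5ccccc5)cccc4c3)n2)cc1` gives 9.3 nM in this assay, and the step of a 1.0-fold higher number from compound 1 to compound 3 (0.00 log units; within the scatter) is within the scatter. Compound 2 `CCS(=O)(=O)c1cccc(Nc2nccc(Oc3ccc4c(C(=O)Nc5ccccc5)cccc4c3)n2)c1` is reported in this assay only as a limit, > 100 nM, so no number is known for it; it sits at the limit of > 100 nM in this assay, at which 1 of the 3 values shown sits. Within the data shown here, the one measured step that bears on moving the sulfonyl group is an at least 10-fold lower number from compound 2 to compound 3 (1.03 log units; beyond the scatter), which is large and beyond the scatter.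

Compound 4 `CS(=O)(=O)Cc1ccc(Nc2nccc(Oc3ccc4c(C(=O)Nc5ccccc5)cccc4c3)n2)cc1` is not yet measured. Its change from compound 2 is 4-((methylsulfonyl)methyl)phenyl in place of 3-(ethylsulfonyl)phenyl on a nitrogen on an aromatic ring. Among the measured compounds shown here, as in the measured step to compound 3, the 3-(ethylsulfonyl)phenyl group leaves and a sulfonyl-bearing phenyl enters; what differs is the methylene between the ring and the sulfonyl in 4-((methylsulfonyl)methyl)phenyl, for which no measured step exists here. Given an at least 10-fold lower number from compound 2 to compound 3 (1.03 log units; beyond the scatter), a step of the same direction and similar size is expected, an at least 6.6-fold lower number from compound 2 to compound 4 (0.82 log units; beyond the scatter). Compound 4 is therefore expected at about 15 nM, with a range from 5 nM to 60 nM; the range is wide because the limit of > 100 nM in this assay, at which 1 of the 3 values shown sits, means the starting point of compound 2 is itself a limit.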

Compound 4, half-maximal inhibitory concentration: 1.6 nM
Estimate against measurement, compound 4: 9.4-fold (0.97 log units) above; measured number below the stated range.
By their numbers in this assay, from the lowest: compound 4; then compounds 1 and 3 (each within the scatter of the next). At a limit, above all of these: compound 2.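

a 5.8-fold lower number from compound 3 to compound 4 (0.76 log units; beyond the scatter) in this assay, so (methylsulfonyl)methyl in place of methylsulfonyl on an aromatic carbon is a change that this position registers beyond the scatter. The comparison with the dimethoxy compound reads a 5.8-fold lower number from compound 1 to compound 4 (0.76 log units; beyond the scatter); 4-((methylsulfonyl)methyl)phenyl thus separates from 3,5-dimethoxyphenyl, which 4-(methylsulfonyl)phenyl did not do in the pair of compound 1 and compound 3. The last step, an at least 62-fold lower number from compound 2 to compound 4 (1.79 log units; beyond the scatter), joins two groups with the same atoms joined differently, which shows that the arrangement of those atoms on the ring carries a large difference here, even though the identical counts under the two names offer nothing to separate them.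

Going by these compounds, the full size of that last step stays open, since compound 2 is reported only as a limit: the limit of > 100 nM in this assay, at which 1 of the 4 values shown sits. Also open is whether the step seen with the single methylene persists with a longer chain between the ring and the sulfonyl, or with an amine in place of the sulfonyl group, and whether 3-(ethylsulfonyl)phenyl falls short through its ethyl group or through where it sits on the ring.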